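The source may hold more compounds than are shown below. What is called first, only, known or untested is meant among the compounds shown, and "the series" means these compounds.

Compound 2 `Cc1cc(C)cc(NC(=O)CN2CCC(c3cccc[n+]3[O-])CC2)c1` is tested in a functional assay on HEK293 cells for agonist activity at D(4) dopamine receptor (Homo sapiens), read by FLIPR (a lower number here means a smaller maximal response, a higher number a larger maximal response), where compound 2 gives 76%. Compound 1 `Cc1cccc(NC(=O)CN2CCC(c3ccccc3C#N)CC2)c1` gives 71% in this assay, and compound 3 `Cc1cccc(NC(=O)CN2CCC(c3cccc(O)c3)CC2)c1` gives 66%; all three numbers lie within the usual scatter of one another. Among the measured compounds shown here, the only step that has been taken, a number 5 percentage points lower from compound 1 to compound 3 (within the scatter), alters the group on the saturated ring carbon and leaves the amide side untouched. Compound 4 `O=C(CN1CCC(c2cccc[n+]2[O-])CC1)NC1CCCCC1` differs from compound 2 at that amide side: cyclohexyl in place of 3,5-dimethylphenyl on an amide-type nitrogen. For the measured compounds named here, no measured step touches this position, so nothing indicates a change beyond the scatter. For compound 4 in this assay the expected value is therefore 72%, within 55% to 88%, an expected step of a number 4 percentage points lower from compound 2 to compound 4 (within the scatter).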

Compound 4, largest response reached (reported as efficacy), in percent of the reference or control that the assay uses: 58%
The estimate for compound 4 lay 14 percentage points above the measured number; the range from low to high includes it.
By their numbers in this assay, from the lowest: compounds 4, 3, 1 and 2 (each within the scatter of the next, the first and the last beyond it).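

Cyclohexyl in place of 3,5-dimethylphenyl on an amide-type nitrogen gives a number 18 percentage points lower from compound 2 to compound 4 (beyond the scatter), the first step shown beyond the scatter in this assay. Among the compounds shown here, the only earlier step changed the group on a saturated ring carbon and stayed within the scatter, so this pair shows that the maximal response can shift with the amide-side group. Nothing available explains this drop.

The compounds shown leave open whether the aromatic ring or its two methyl groups matter, which an unsubstituted phenyl or a benzyl on that nitrogen would address. Going by these compounds, whether the step holds with other groups on the saturated ring carbon also remains open.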